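This account rests on a few compounds, and the source may have more. Where it says the series, first, only, none or still open, it means among the compounds named here.

Measured so far:
compound 1, `COC(CCn1cnc2c(NCc3ccc(C(=O)Nc4ccccc4N)cc3)nc(Cl)nc21)OC`: 34.2%
compound 2, `CCCCn1cnc2c(Nc3cccc(Cl)c3)nc(NCOCc3ccc(/C=C/C(=O)Nc4ccccc4N)cc3)nc21`: 30.4%

Among the measured compounds shown here, compound 1 holds the higher of the two numbers so far in a functional assay on HepG2 cells (Homo sapiens) for antiproliferative activity, read by CCK-8 assay, with a stated time of 72 h, tested at 8 uM (a lower number here means a weaker effect, a higher number a stronger effect of the compound at the concentration tested), where compound 1 gives 34.2% against compound 2 at 30.4%; the gap between them lies within the scatter, so the two stand level and neither is called the stronger. For the measured compounds named here, both carry the same anilide end, but the two cores and their substituents differ in several places at once, and no single-point step between measured compounds is available from this pair.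

The next compound, compound 3, `CCC(C)n1cnc2c(NCc3ccc(C(=O)Nc4ccccc4N)cc3)nc(Cl)nc21`, is taken from compound 1 by one change:
sec-butyl in place of 3,3-dimethoxypropyl on an aromatic nitrogen
The 3,3-dimethoxypropyl leaves and a sec-butyl enters, both without a ring and without a net charge, the entering group carrying no hydrogen-bond acceptors.

With no measured step of this kind in the set, the expected step is estimated as small, tending slightly downward, at a number 3.2 percentage points lower from compound 1 to compound 3 (within the scatter) in this assay, which would stay within the scatter. Compound 3 is therefore expected near 31%, with a range of 18% to 44%.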

Compound 3, a percentage reported as inhibition, at one concentration (the size of the read-out at that concentration, not a potency): 65%
Compound 3: middle estimate off by 34 percentage points, on the low side; measured number above the stated range.
By their numbers in this assay, from the lowest: compounds 2 and 1 (each within the scatter of the next); then compound 3.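

In this assay, the group on the aromatic nitrogen of the five-membered ring carries a large effect: sec-butyl in place of 3,3-dimethoxypropyl gives a number 30.8 percentage points higher from compound 1 to compound 3 (beyond the scatter), with the rest of the structure unchanged, a single-place reading that the earlier pair of compounds, differing in several places at once, could not give. The change removes the oxygen atoms and all hydrogen-bond acceptors from this group and also leaves it with fewer heavy atoms, so this one step cannot separate these differences from each other. No measured information on hand accounts for the size of the step.

Still open, as far as these compounds go, is how the number responds to other groups at this nitrogen, such as an isopropyl, a cyclopentyl or a 3-hydroxypropyl chain, which could show whether the oxygen atoms, the chain length or the branching of sec-butyl tracks with the read-out. From the compounds shown here alone, the read-out also comes from a single concentration, so it shows a stronger effect for compound 3 than for compound 1 at that concentration only, and how the two compare at other concentrations remains open.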